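A few compounds are considered here, and "the series" means these few. Any claim that something is new, unique, unknown or untested is made for them only; others in the source may bear on it.

Going by the values given here, compound 2 `COc1cc(/C=N/Nc2nc(-c3ccc(F)c(F)c3)cs2)c(Br)c(Br)c1OC` is the one member with a number here; in an ADME assay on HUVEC cells (Homo sapiens) for inhibition, read by MTT assay, with a stated time of 48 h (a lower number here means a stronger inhibitor, a higher number a weaker inhibitor), compound 2 gives 54700 nM. Compound 1 `COc1cc(/C=N/Nc2nc(-c3ccc(F)c(F)c3)cs2)cc(Br)c1OC` reaches only the limit of this assay, reading > 100000 nM. Compound 3 `Fc1ccc(/C=N/Nc2nc(-c3ccc(Br)cc3)cs2)cc1F` likewise reaches only the limit of this assay, reading > 100000 nM. The step of an at least 1.8-fold higher number from compound 2 to compound 1 (0.26 log units; that floor lies within the scatter) follows the change (hydrogen in place of bromo on an aromatic carbon). How the core of compound 3 differs from the core of compound 2 is not broken down here. Compound 4 `Fc1ccc(/C=N/Nc2nc(-c3ccccc3)cs2)cc1F` differs from compound 3 by hydrogen in place of bromo on an aromatic carbon, the same kind of change, though here the place is para to a large group rather than ortho to a bromo group, ortho to a large group, meta to a methoxy group and para to a methoxy group. For compound 4 a step that the limit leaves unreadable from compound 3 to compound 4 is expected, resting on an at least 1.8-fold higher number from compound 2 to compound 1 (0.26 log units; that floor lies within the scatter) and on (the limit of > 100000 nM in this assay, at which 2 of the 3 values shown sit). Compound 4 is thus estimated at 150000 nM, between 60000 nM and 400000 nM, most probably again reported only as a limit.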

Compound 4, half-maximal inhibitory concentration: > 100000 nM
Compound 4: a limit, no number; the forecaster's own chance of this, stated with the estimate: 85%; the middle value lies beyond the limit too.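

Compound 3 and compound 4 both stand at a limit in this assay, so no new step can be read between them: the limit of > 100000 nM in this assay, at which 3 of the 4 values shown sit. On these data alone, whether the change from 4-bromophenyl to phenyl alters inhibition at all stays open.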